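Anilino Sulfone Series: Para Substituent Swap to Chloro

This account rests on a few compounds, and the source may have more. Where it says the series, first, only, none or still open, it means among the compounds named here.

Measured compounds:
- Compound 1 `COc1cc(Nc2ccc3c(c2)S(=O)(=O)C=C3)cc(OC)c1OC`: 1880 nM
- Compound 2 `O=S1(=O)C=Cc2cccc(Nc3ccc(OC(F)(F)F)cc3)c21`: 1570 nM
- Compound 3 `O=S1(=O)C=Cc2cccc(Nc3ccc(C(F)(F)F)cc3)c21`: 2440 nM

All three share the same core and differ only in the substituents on the anilino ring. In a functional assay on A549 cells (Homo sapiens) for antiproliferative activity, read by MTT assay, with a stated time of 72 h (on this read-out higher numbers stand for weaker inhibition and lower numbers for stronger inhibition), compound 3 gives the highest of the three numbers, but its gaps to compound 1 and compound 2 are both within the scatter, so the three values cannot be ordered.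

Compound 4 `O=S1(=O)C=Cc2cccc(Nc3ccc(Cl)cc3)c21` is the next member. Change: chloro in place of trifluoromethyl on an aromatic carbon

For the measured compounds named here, only one measured step touches the same position: a 1.6-fold higher number from compound 2 to compound 3 (0.19 log units; within the scatter), a swap between two groups at the same place that left the value essentially unchanged. Nothing else in the series bears on a halogen at that place. Going by the values given here, with that single, flat step as the only guide, the expected change from compound 3 to compound 4 in this assay is a 1.2-fold lower number from compound 3 to compound 4 (0.09 log units; within the scatter), none beyond the scatter in either direction.

Among the compounds with values here, compound 4 is therefore estimated at 2000 nM, with a range from 900 nM to 4500 nM; the range is wide because the single related step of a 1.6-fold higher number from compound 2 to compound 3 (0.19 log units; within the scatter) constrains the outcome only weakly.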

Compound 4, half-maximal inhibitory concentration: 1040 nM
The estimate for compound 4 lay 1.9-fold (0.28 log units) above the measured number; low and high end bracket the measured number.
By their numbers in this assay, from the lowest: compounds 4, 2, 1 and 3 (each within the scatter of the next, the first and the last beyond it).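

In this assay, for the compounds shown here, chloro in place of trifluoromethyl gives a 2.3-fold lower number from compound 3 to compound 4 (0.37 log units; beyond the scatter) and is the first step at this aromatic carbon to pass beyond the scatter, so the read-out does respond to a change at this place, if only modestly. Chloro in place of trifluoromethoxy gives a 1.5-fold lower number from compound 2 to compound 4 (0.18 log units; within the scatter) and does not separate those two groups, which leaves compound 3 and compound 4 as the only pair at this place that stands apart. Nothing measured here offers an explanation for the step.

As far as these compounds go, whether fluoro, bromo, an amine or a carboxylic acid at this place would fall within the span set by compound 4 and compound 3 remains open. Also open, from the compounds shown here alone, is whether chloro in place of trifluoromethyl would give a similar step on other anilino patterns.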